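This account rests on a few compounds, and the source may have more. Where it says the series, first, only, none or still open, it means among the compounds named here.

Measured compounds:
- compound 1, `NC1=NC2(CCSCC2)N(OCCCOc2cccc(Cl)c2Cl)C(N)=N1`: 50 nM
- compound 2, `NC1=NC2(CCOCC2)N(OCCCOc2ccccc2Cl)C(N)=N1`: 1750 nM
- compound 3, `NC1=NC2(CCOCC2)N(OCCCOc2ccccc2)C(N)=N1`: "not determined" (no result reported)

All three share one core, and the numbers come from a functional assay on HepG2 cells (Homo sapiens) for antiproliferative activity, read by MTT assay, with a stated time of 72 h; on this read-out higher numbers stand for weaker inhibition and lower numbers for stronger inhibition. Compound 1 has the lowest number of the two that were determined. Its nearest neighbour is compound 2, which in this assay gives 1750 nM, a far higher number than compound 1 and well beyond the usual scatter of the method; compound 2 differs from compound 1 both in the ring fused to the core and in the dichlorophenyl group, so the two values cannot be tied to a single change. Compound 3, with a plain phenyl, has no reported result.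

Compound 4, `NC1=NC2(CCSCC2)N(OCCCOc2ccc(Cl)c(Cl)c2)C(N)=N1`, is not yet measured. It differs from compound 1 only in one place: 3,4-dichlorophenyl in place of 2,3-dichlorophenyl on an oxygen on a saturated carbon. Among the compounds with values here, no measured pair shows this change on its own. In this assay a modest weakening is expected for compound 4, roughly at the edge of the scatter, since moving both chlorines is a rearrangement of the same atoms rather than a loss or gain of any group. The expected step is a 2.4-fold higher number from compound 1 to compound 4 (0.38 log units; beyond the scatter). The estimated value for compound 4 is 120 nM, within a range from 30 nM to 500 nM.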

Compound 4, half-maximal inhibitory concentration: 70 nM
For compound 4 the middle estimate is 1.7-fold (0.23 log units) above the measured one, and the stated range covers the measured number.
By their numbers in this assay, from the lowest: compounds 1 and 4 (each within the scatter of the next); then compound 2.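

Within the data shown here, compound 1 and compound 4 form the first pair here that differs in only one place, so this change can be read on its own. In this assay, putting 3,4-dichlorophenyl in place of 2,3-dichlorophenyl on an oxygen on a saturated carbon gives a 1.4-fold higher number from compound 1 to compound 4 (0.15 log units; within the scatter), so the two numbers cannot be told apart and, for this pair, the arrangement of the two chlorines on the ring makes no measurable difference. Nothing available here offers a measurement that would explain this result.

Compound 2, at 1750 nM, still differs from compound 1 in two places, so the compounds shown do not reveal whether its much higher number comes from the ring fused to the core, from having a single chlorine, or from both together. Also open, from the compounds shown here alone, is whether this result extends beyond two chlorines, for instance to a phenyl ring carrying methoxy or trifluoromethyl, or to a longer chain linking the ring to the core.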